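A few compounds are considered here, and "the series" means these few. Any claim that something is new, unique, unknown or untested is made for them only; others in the source may bear on it.

Measured compounds so far:
- compound 1, `O=C(Nc1cccc(-n2cc(-c3ccncc3)c(-c3ccc(Cl)c(O)c3)n2)c1)Nc1ccc(Cl)c(Cl)c1`; in a functional assay on PC-3 cells (Homo sapiens) for inhibition, read by sulforhodamine B assay, with a stated time of 48 h (a higher number here means that more compound is tolerated, a lower number that less compound is tolerated), compound 1 gives > 32500 nM, which is a limit of the assay and not a number.
- compound 2, `O=C(Nc1cccc(-n2cc(-c3ccncc3)c(-c3ccc(Cl)c(O)c3)n2)c1)Nc1cc(C(F)(F)F)cc(C(F)(F)F)c1`; in this assay compound 2 gives > 50000 nM, again a limit of the assay rather than a number.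

Where compound 2 stands: only a limit is known for it in this assay, namely (the limit of > 50000 nM in this assay, at which 1 of the 2 values shown sits). Among the compounds with values here, the one further value shown, for compound 1, is also a limit, (the limit of > 32500 nM in this assay, at which 1 of the 2 values shown sits). Within the data shown here, no pair of measured compounds differs in one place only, so no measured step is available, and the two limits cannot be compared with each other beyond saying that neither compound reached a lethal concentration within the range tested.

The step to follow leads to compound 3, `O=C(Nc1cccc(-n2cc(-c3ccncc3)c(-c3ccc(Cl)c(O)c3)n2)c1)Nc1cccc(C(F)(F)F)c1`. Relative to compound 2 the change is hydrogen in place of trifluoromethyl on an aromatic carbon.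

Expectation: with both measured values sitting at limits, no direction can be read for this assay, and the step from compound 2 to compound 3 is expected to be none beyond the scatter, an at least 1.2-fold lower number from compound 2 to compound 3 (0.09 log units; that floor lies within the scatter). Compound 3 is therefore estimated at 40000 nM, with a range from 12000 nM to 100000 nM, most likely reported again as a limit.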

Compound 3, concentration lethal to 50% of the cells: > 32500 nM
Compound 3: only a limit was reported (the forecaster's own chance of this, stated with the estimate: 70%); the middle value is on the limit's open side.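

In this assay compound 3 gives > 32500 nM, which is a limit of the assay and not a number. Within the data shown here, no step to compound 3 from compound 1 or compound 2 can be read. The compounds shown leave open where any true value in this assay lies, and whether the aromatic group on the amide-type nitrogen matters at all.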